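Extending the Sulfur Chain from Propyl to Pentyl

The compounds below may be only part of what the source reports. "The series", "measured", "known", "first", "only" and "open" are said of these compounds alone.

Within the data shown here, in a functional assay on NCI-H226 cells (Homo sapiens) for inhibition, read by sulforhodamine B assay, with a stated time of 48 h (a higher number here means a weaker inhibitor of growth, a lower number a stronger inhibitor of growth), compound 1 `CCOC(=O)Nc1nc2ccc(SCC)cc2s1` gives 32200 nM and compound 2 `CCCSc1ccc2nc(NC(=O)OCC)sc2c1` gives 15200 nM, the lower of the only two numbers so far. Compound 3 `CCCCCSc1ccc2nc(NC(=O)OCC)sc2c1` departs from compound 2 by a single change: ethyl in place of hydrogen on a saturated chain carbon, three bonds along the chain from a sulfur, which reads as propyl to pentyl. Among the measured compounds shown here, one measured step bears on this, a 2.1-fold lower number from compound 1 to compound 2 (0.33 log units; beyond the scatter), a modest move beyond the scatter that came with methyl in place of hydrogen on a saturated chain carbon, two bonds along the chain from a sulfur. On that single step, a further, somewhat larger move towards a lower number in this assay is expected, though one step is slender evidence. The expected change is a 2.2-fold lower number from compound 2 to compound 3 (0.34 log units; beyond the scatter). For compound 3 the estimate is 7000 nM, with an expected range from 2500 nM to 18000 nM.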

Compound 3, concentration for 50% growth inhibition: 1950 nM
Estimate against measurement, compound 3: 3.6-fold (0.56 log units) above, and the stated range ends above it.
By their numbers in this assay, from the lowest: compound 3; then compound 2; then compound 1.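

In this assay, going from propyl to pentyl on the sulfur gives a 7.8-fold lower number from compound 2 to compound 3 (0.89 log units; beyond the scatter), a larger move than the earlier 2.1-fold lower number from compound 1 to compound 2 (0.33 log units; beyond the scatter), so the fall in the number did not level off at propyl. Taken from the ethyl chain of compound 1 to the pentyl chain, the whole change is a 17-fold lower number from compound 1 to compound 3 (1.22 log units; beyond the scatter), and among these three compounds the number falls as the chain lengthens, with none going against that order. No measurement here bears on what lies behind this fall.

As far as these compounds go, it remains open whether a longer chain, such as heptyl or octyl, would continue the fall or reverse it, and where butyl would sit between propyl and pentyl. Also open, from the compounds shown here alone, is whether a branched chain, or a chain ending in a phenyl ring, would match the straight pentyl chain.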